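The compounds below may be only part of what the source reports. "The series", "measured", "known", "first", "only" and "open" are said of these compounds alone.

Working notes on the series. In a functional assay on MIA PaCa-2 cells (Homo sapiens) for inhibition, read by MTT assay, with a stated time of 3 days (a higher number here means a weaker inhibitor, a lower number a stronger inhibitor), compound 2 `CCN(CC)S(=O)(=O)c1ccc(S(=O)(=O)N2CCC[C@@H](C(=O)N3CCC(c4nc(C(C)C)no4)CC3)C2)cc1` gives > 10000 nM, which is a limit of the assay and not a number. Compound 1 `CCOC(=O)[C@@H]1CCCN(S(=N)(=O)c2ccc(S(=O)(=O)N(CC)CC)cc2)C1` in this assay gives > 10000 nM, likewise a limit. Among the measured compounds shown here, both values thus sit at the limit of > 10000 nM in this assay, at which 2 of the 2 values shown sit, so compound 2 stands at the same limit as compound 1, and no measured step with a size exists between them.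

Compound 3 `CC(C)c1noc(C2CCN(C(=O)[C@@H]3CCCN(S(=O)(=O)c4ccc(S(=O)(=O)C(C)C)cc4)C3)CC2)n1` differs from compound 2 by isopropyl in place of diethylamino on a sulfonyl sulfur. For the measured compounds named here, with no measured step in this assay, no shift beyond the scatter is expected from this change. Compound 3 is therefore expected to give about 15000 nM, between 4000 nM and 60000 nM, most likely again as a limit. The expected step that the limit leaves unreadable from compound 2 to compound 3 is estimated as none beyond the scatter.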

Compound 3, half-maximal inhibitory concentration: > 10000 nM
Compound 3: only a limit was reported; the forecaster's own chance of this, stated with the estimate: 80%; the middle value lies beyond the limit too.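

No step can be read between compound 2 and compound 3, as both stand at a limit: the limit of > 10000 nM in this assay, at which 3 of the 3 values shown sit.

The compounds shown leave open whether isopropyl in place of diethylamino on a sulfonyl sulfur changes inhibition at all in this assay.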